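The compounds below may be only part of what the source reports. "The series", "measured", "known", "first", "only" and "open" are said of these compounds alone.

Measured in an assay on isolated protein for agonist activity at melatonin receptor type 1C (Xenopus laevis), read by spectrophotometry; a higher number here means a larger maximal response, a lower number a smaller maximal response:

compound 1 `COc1ccc(F)c(CNC(C)=O)c1` — 100%
compound 2 `COc1cc(CNC(C)=O)ccc1F` — 83%
compound 3 `CCC(=O)NCc1ccc(F)c(OC)c1` — 86%

Compound 3 stands second highest of the three. Its nearest neighbour is compound 2, whose largest response is a little lower, a gap that lies within the scatter of repeated measurements. Its furthest neighbour is compound 1, whose largest response is higher by more than the scatter, so that pair is the only one among the three that is truly separated.

Compound 4 `CCCC(=O)NCc1ccc(F)c(OC)c1` differs from compound 3 in one place: methyl in place of hydrogen on a saturated chain carbon, two bonds along the chain from a carbonyl carbon. For the measured compounds named here, one measured step bears on this, since it is the same kind of chain growth made one bond nearer the carbonyl carbon: a number 3 percentage points higher from compound 2 to compound 3 (within the scatter). That step lay within the scatter, and there is no other information about chain length in this set. The expected step in this assay is therefore a number 1 percentage points lower from compound 3 to compound 4 (within the scatter), no shift beyond the scatter in either direction. Compound 4 is thus estimated at 85%, with a range from 70% to 98%.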

Compound 4, largest response reached (reported as efficacy), in percent of the reference or control that the assay uses: 75%
The estimate for compound 4 lay 10 percentage points above the measured number, and the stated range covers the measured number.
By their numbers in this assay, from the lowest: compounds 4, 2 and 3 (each within the scatter of the next, the first and the last beyond it); then compound 1.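

In this assay, for the compounds shown here, the change from ethyl to propyl on the carbonyl carbon gives the only chain step here that lies beyond the scatter, with a number 11 percentage points lower from compound 3 to compound 4 (beyond the scatter), so this outer position tolerates added carbon less well than the earlier step suggested. Counted from the shorter amide, the whole addition reads a number 8 percentage points lower from compound 2 to compound 4 (within the scatter), and so the full ethyl extension stays within the scatter even though its last methyl alone does not. Nothing available explains this loss of maximal response at the added methyl.

On these data alone, whether a longer chain such as butyl lowers the response further, or a branched isopropyl or a cyclopropyl ring behaves like the propyl chain, remains open. Equally open, as far as these compounds go, is whether the same propylcarbonyl chain on the core of compound 1 would give a similar step.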